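Replacing the aryl group of compound 3

The source may report more compounds than this note shows. Statements on the series, on what has been measured and on what is new or still open speak of the compounds shown alone.

Compound 1 `COc1ccc(NC(=O)CN2CCN(c3nnc(Cc4ccncc4)c4ccccc34)CC2)cc1OC` gives 100 nM
Compound 2 `O=C(CN1CCN(c2nnc(Cc3ccncc3)c3ccccc23)CC1)Nc1ccc(Br)cc1` gives 19 nM
Compound 3 `O=C(CN1CCN(c2nnc(Cc3ccncc3)c3ccccc23)CC1)Nc1cc(C(F)(F)F)ccc1Cl` gives 3.7 nM

All three values come from a functional assay on MDA-MB-231 cells (Homo sapiens) for cytotoxicity, read by MTT assay, with a stated time of 72 h (a higher number here means a weaker inhibitor, a lower number a stronger inhibitor), and compound 3 stands lowest among them, with both of its steps beyond the scatter. The step of a 5.1-fold lower number from compound 2 to compound 3 (0.71 log units; beyond the scatter) is modest, while a 27-fold lower number from compound 1 to compound 3 (1.43 log units; beyond the scatter) is large.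

Next comes compound 4 `O=C(CN1CCN(c2nnc(Cc3ccncc3)c3ccccc23)CC1)Nc1ccc(F)c(F)c1` as yet unmeasured. The change is 3,4-difluorophenyl in place of 2-chloro-5-(trifluoromethyl)phenyl on an amide-type nitrogen with 3,4-difluorophenyl in place of 2-chloro-5-(trifluoromethyl)phenyl on an amide-type nitrogen, and the shared core stays as it is.

Among the measured compounds shown here, all the measured steps alter the group at this same place. The third of them is a 5.3-fold lower number from compound 1 to compound 2 (0.72 log units; beyond the scatter) and it too lies beyond the scatter, so changes here have moved the number in this assay by modest to large amounts. For the measured compounds named here, no measured compound carries the 3,4-difluorophenyl group, which leaves three values as only a rough guide. Compound 1 and compound 2 both show higher numbers than compound 3, so a rise is expected, nearer in size to a 5.1-fold lower number from compound 2 to compound 3 (0.71 log units; beyond the scatter) than to a 27-fold lower number from compound 1 to compound 3 (1.43 log units; beyond the scatter) in the comparison above.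

The expected outcome is a 5.4-fold higher number from compound 3 to compound 4 (0.73 log units; beyond the scatter) as a modest step. In this assay the estimate for compound 4 is 20 nM with an expected range from 6 nM to 70 nM as its bounds.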

Compound 4, half-maximal inhibitory concentration: 0.84 nM
Estimate against measurement, compound 4: 24-fold (1.38 log units) above; measured number outside the range, below it.
By their numbers in this assay, from the lowest: compound 4; then compound 3; then compound 2; then compound 1.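

In this assay, the 3,4-difluorophenyl group on the amide-type nitrogen lowers the number further (a 4.4-fold lower number from compound 3 to compound 4 (0.64 log units; beyond the scatter)), so the 2-chloro-5-(trifluoromethyl)phenyl group of compound 3 does not mark the low end at this position, and a group with fewer heavy atoms can go lower. The gaps to the other aryl groups (a 23-fold lower number from compound 2 to compound 4 (1.35 log units; beyond the scatter); a 120-fold lower number from compound 1 to compound 4 (2.08 log units; beyond the scatter)) show that this single position spans a wider range than the first three compounds revealed, with compound 4 lowest of the four and all its steps beyond the scatter. Nothing available accounts for why this group gives the lowest number.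

It remains open whether both fluorines are needed, as the 3-fluorophenyl and 4-fluorophenyl groups do not appear among these compounds. Also unresolved is how far the position extends beyond halogen-bearing phenyl groups, for example to a phenyl ring carrying an amine or a carboxylic acid, or to a saturated cyclohexyl ring on the amide-type nitrogen.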